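The source may report more compounds than this note shows. Statements on the series, on what has been measured and on what is new or still open speak of the compounds shown alone.

Measured compounds:
Compound 1, `CCOC(=O)CNc1nc(Nc2cccc(OC)c2)ncc1[N+](=O)[O-]`; in a functional assay on A549 cells (Homo sapiens) for antiproliferative activity, read by MTT assay, with a stated time of 48 h (on this read-out higher numbers stand for weaker inhibition and lower numbers for stronger inhibition), compound 1 gives 36100 nM.
Compound 2, `CCOC(=O)CN(Cc1ccccc1)c1nc(Nc2ccc(Cl)cc2)ncc1[N+](=O)[O-]`; in this assay compound 2 gives > 100000 nM, which is a limit of the assay.
Compound 3, `CCOC(=O)CN(Cc1ccccc1)c1nc(Nc2ccccc2)ncc1[N+](=O)[O-]`; in this assay compound 3 gives > 100000 nM, which is also a limit of the assay.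

Compound 3 therefore stands at the limit of > 100000 nM in this assay, at which 2 of the 3 values shown sit, not at a number. Among the measured compounds shown here, the one measured step that touches it, a step that the two limits leave unreadable from compound 2 to compound 3, cannot be read in size, since both ends sit at the limit. Compound 4, `CCOC(=O)CN(Cc1ccccc1)c1nc(Nc2cccc(OC)c2)ncc1[N+](=O)[O-]`, differs from compound 3 by methoxy in place of hydrogen on an aromatic carbon. No measured step carries this same change, so nothing shown tells how large a shift to expect in this assay or in which direction. Compound 1 also bears the methoxy group but differs from compound 4 in more than one place, and it alone among the three gives a number rather than a limit. Given this, compound 4 is expected to stay close to where compound 3 sits, with a step of a number no higher from compound 3 to compound 4 (the limit leaves the size open) that is not expected to exceed the scatter. The estimate for compound 4 is 100000 nM, within a range of 30000 nM to 300000 nM, most likely reported as a limit.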

Compound 4, half-maximal inhibitory concentration: > 100000 nM
Compound 4: no number, only a limit; the forecaster's own chance of this, stated with the estimate: 65%; the middle value sits exactly at the limit.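

In this assay compound 4 gives > 100000 nM, which is a limit of the assay and not a number. The 3-methoxyphenyl group therefore does not lift a compound that carries benzyl on the nitrogen off that limit, and the steps among compounds 2, 3 and 4 cannot be read, so the limit is where the series stands: the limit of > 100000 nM in this assay, at which 3 of the 4 values shown sit. The one readable step isolates the benzyl group, as benzyl in place of hydrogen on the nitrogen gives an at least 2.7-fold higher number from compound 1 to compound 4 (0.44 log units; beyond the scatter), and among these compounds only the one with hydrogen there gives a number.

Going by these compounds, how far the benzyl compounds lie past the limit stays open, as does what the methoxy group does when that nitrogen carries hydrogen. Also open, on these data alone, is whether a methyl on that nitrogen, or a carboxylic acid in place of the ethyl ester, would give a number.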